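The source may hold more compounds than are shown below. What is called first, only, known or untested is meant among the compounds shown, and "the series" means these compounds.

For the measured compounds named here, compound 2 `O=C(/C=C/c1cn(-c2ccccc2)nc1-c1cccnc1)c1ccsc1` gives 1300 nM in a functional assay on HCT-116 cells (Homo sapiens) for inhibition, read by sulforhodamine B assay, with a stated time of 72 h (a lower number here means a stronger inhibitor, a higher number a weaker inhibitor), the lowest of the two numbers measured so far; compound 1 `O=C(/C=C/c1cn(-c2ccccc2)nc1-c1ccsc1)c1ccccc1` gives 5100 nM in this assay, a difference that lies beyond the scatter. Compound 3 `COc1ccc(OC)c(C(=O)/C=C/c2cn(-c3ccccc3)nc2-c2cccnc2)c1` differs from compound 2 in one place: 2,5-dimethoxyphenyl in place of thiophen-3-yl on a carbonyl carbon. Going by the values given here, no measured pair shows this exchange, so nothing here tells how large a step to expect. Compound 3 is therefore expected to stay close to compound 2, with the step of a 1.2-fold higher number from compound 2 to compound 3 (0.06 log units; within the scatter) estimated as none beyond the scatter. The estimate for compound 3 is 1500 nM, within a range from 500 nM to 5000 nM.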

Compound 3, half-maximal inhibitory concentration: 1000 nM
Estimate against measurement, compound 3: 1.5-fold (0.18 log units) above; measured number inside the range.
By their numbers in this assay, from the lowest: compounds 3 and 2 (each within the scatter of the next); then compound 1.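

In this assay, placing 2,5-dimethoxyphenyl instead of thiophen-3-yl on the carbonyl carbon gives a 1.3-fold lower number from compound 2 to compound 3 (0.11 log units; within the scatter). This position therefore takes a group of 10 heavy atoms with a six-membered carbon ring in place of one of 5 heavy atoms with a sulfur-containing five-membered ring, with no change beyond the scatter. No measurement available here explains why the two groups score alike.

From the compounds shown here alone, whether the same holds for a different kind of group on this carbon, such as an amine or a carboxylic acid, stays open. Going by these compounds, the separate contribution of each methoxy group also stays open.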